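Compound 3: a methyl shift in a series at the limit

The compounds below may be only part of what the source reports. "The series", "measured", "known", "first", "only" and "open" are said of these compounds alone.

In an ADME assay on Vero cells (Chlorocebus sabaeus) for antiproliferative activity, read by MTT assay, with a stated time of 72 h (on this read-out higher numbers stand for weaker inhibition and lower numbers for stronger inhibition), compound 1 (`CN(c1cccc2ccccc12)S(=O)(=O)C1CC2OC1C(c1ccc(NC(=O)CCCCCCC(=O)O)cc1)=C2c1ccc(O)cc1`) gives > 100000 nM, which is a limit of the assay and not a number. Compound 2 (`CCN(c1ccc(C)cc1)S(=O)(=O)C1CC2OC1C(c1ccc(NC(=O)CCCCCCC(=O)O)cc1)=C2c1ccc(O)cc1`) also reads only as a limit, > 100000 nM. For the measured compounds named here, the one measured step, a step that the two limits leave unreadable from compound 1 to compound 2, therefore gives no size to carry forward. Both measured compounds share one position: the limit of > 100000 nM in this assay, at which 2 of the 2 values shown sit.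

Compound 3 (`CCN(c1cccc(C)c1)S(=O)(=O)C1CC2OC1C(c1ccc(NC(=O)CCCCCCC(=O)O)cc1)=C2c1ccc(O)cc1`) differs from compound 2 by 3-methylphenyl in place of 4-methylphenyl on a sulfonamide nitrogen. Going by the values given here, no measured step covers this exchange directly, so the expectation rests on compound 1 and compound 2 both sitting at the limit of > 100000 nM in this assay, at which 2 of the 2 values shown sit. The expected change in this assay is a number no higher from compound 2 to compound 3 (the limit leaves the size open), with no shift beyond the scatter and no direction assigned. For compound 3 the estimate is 100000 nM, within an expected range of 40000 nM to 200000 nM, and a report as a limit is likely.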

Compound 3, half-maximal inhibitory concentration: > 100000 nM
Compound 3: only a limit was reported; the forecaster's own chance of this, stated with the estimate: 85%; the middle value sits exactly at the limit.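

In this assay, for the compounds shown here, compound 3 gives > 100000 nM, a limit of the assay and not a number, so no step among compound 1, compound 2 and compound 3 can be read. Still open, from the compounds shown here alone, is whether any exchange on the sulfonamide nitrogen gives a readable number in this assay.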